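Chain length and the loss of activity at a receptor

The source may hold more compounds than are shown below. What is called first, only, known or untested is meant among the compounds shown, and "the series" means these compounds.

Measured so far:
compound 1, `N#CCCCCc1nc(O)cc(O)n1` — > 100000 nM in a functional assay on HEK293 cells for agonist activity at G-protein coupled receptor 84 (Homo sapiens), read by calcium flux; a higher number here means that more compound is needed for the effect, a lower number that less compound is needed
compound 2, `CCCCCCCCc1cc(O)cc(O)n1` — 1.34 nM in this assay

In this assay compound 1 reaches only a limit, > 100000 nM, so no number is known for it, as the limit of > 100000 nM in this assay, at which 1 of the 2 values shown sits, records. Compound 2, which carries a saturated chain on a different core, gives 1.34 nM in this assay. Compound 3, `CCCCCCCCc1nc(O)cc(O)n1`, is not yet measured. It differs from compound 1 in one place: butyl in place of cyano on a saturated chain carbon, four bonds along the chain from an aromatic carbon. The saturated chain of compound 3 is the same one that compound 2 carries. Since compound 1 sits at a limit, only the direction of the step can be expected, toward less compound being needed. Compound 3 is therefore expected at 20 nM, within 2 nM to 300 nM, which means an expected step of an at least 5000-fold lower number from compound 1 to compound 3 (3.69 log units; beyond the scatter).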

Compound 3, half-maximal effective concentration: 11.4 nM
Compound 3: middle estimate off by 1.8-fold (0.24 log units), on the high side; measured number inside the range.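

At this place on the chain, a saturated chain carbon four bonds along from an aromatic carbon, this assay gives an at least 8700-fold lower number from compound 1 to compound 3 (3.94 log units; beyond the scatter), with butyl in place of cyano. For the compounds shown here, this is the first comparison on this core, and it shows that this single change is enough to turn a compound without a measured number into one with a measured number. The value of compound 1, > 100000 nM, is a limit of the assay and not a number, so the step fixes only a minimum size: the limit of > 100000 nM in this assay, at which 1 of the 3 values shown sits.

The compounds shown leave open how much of the step comes from losing the nitrile and how much from gaining the butyl carbons. They also leave open how a longer chain, an amine or a carboxylic acid in the same place would read in this assay.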